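Sulfanyl to sulfonyl bridge in a diaryl amide series

The compounds below may be only part of what the source reports. "The series", "measured", "known", "first", "only" and "open" are said of these compounds alone.

Of the compounds shown here, three have been measured and a fourth has not. Compound 1 `O=C(Nc1ccc([N+](=O)[O-])c(C(F)(F)F)c1)c1ccc(Sc2ccc(O)cc2)cc1` carries a (4-hydroxyphenyl)sulfanyl group on its core; compound 2 `O=C(Nc1cc(C(F)(F)F)cc(C(F)(F)F)c1)c1ccc(Sc2ccc(O)cc2)cc1` carries the same group on a core that differs elsewhere, and the difference between the two cores is not broken down here. Compound 3 `O=C(Nc1ccc([N+](=O)[O-])c(C(F)(F)F)c1)c1ccc(S(=O)(=O)c2ccc(O)cc2)cc1` is compound 1 with (4-hydroxyphenyl)sulfonyl in place of (4-hydroxyphenyl)sulfanyl on an aromatic carbon. In a functional assay on CWR22R cells (Homo sapiens) for antiproliferative activity, read by fluorescence and propidium iodide staining, with a stated time of 96 h (on this read-out lower numbers stand for stronger inhibition and higher numbers for weaker inhibition), compound 1 gives 4500 nM, compound 2 gives 3350 nM and compound 3 gives 7300 nM. The move from the sulfanyl to the sulfonyl bridge gave a 1.6-fold higher number from compound 1 to compound 3 (0.21 log units; within the scatter). Compound 1 and compound 2 lie within the scatter of each other, while compound 3 shows a higher number than compound 2, beyond the scatter.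

Compound 4 `O=C(Nc1cc(C(F)(F)F)cc(C(F)(F)F)c1)c1ccc(S(=O)(=O)c2ccc(O)cc2)cc1`, not yet measured, is compound 2 with (4-hydroxyphenyl)sulfonyl in place of (4-hydroxyphenyl)sulfanyl on an aromatic carbon, the same change at the same place as from compound 1 to compound 3. Among the measured compounds shown here, from compound 2 to compound 4 a step of about a 1.6-fold higher number from compound 2 to compound 4 (0.21 log units; within the scatter) is expected in this assay, resting on the single earlier step, which itself lay within the scatter. For compound 4 the expected value is 5400 nM, between 2700 nM and 11000 nM.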

Compound 4, half-maximal inhibitory concentration: 6440 nM
The estimate for compound 4 lay 1.2-fold (0.08 log units) below the measured number; the measured number falls inside the stated range.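

In this assay, (4-hydroxyphenyl)sulfonyl in place of (4-hydroxyphenyl)sulfanyl on the core of compound 2 gives a 1.9-fold higher number from compound 2 to compound 4 (0.28 log units; within the scatter). Set beside the earlier step, the change behaves alike on the two cores, with no difference between them that can be told apart: the same change on two cores in this assay, a 1.6-fold higher number (0.21 log units; within the scatter) from compound 1 to compound 3 and a 1.9-fold higher number (0.28 log units; within the scatter) from compound 2 to compound 4, 1.2-fold (0.07 log units) apart, within the scatter of two such steps. This shows that the size of the step carries over from the core of compound 1 to the core of compound 2, but each step lies within the scatter on its own, so the two together do not establish a real effect of the change, and two cores say nothing about a third.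

Still open is how the step would run with a sulfinyl bridge, an ether oxygen or a methylene group in place of the sulfur-containing bridges shown. Also open, on these data alone, is whether it would hold with an amine or a carboxylic acid in place of the hydroxy group on the 4-hydroxyphenyl ring.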